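The compounds below may be only part of what the source reports. "The series", "measured", "known", "first", "only" and "open" are said of these compounds alone.

The study compares four compounds in a functional assay on SW1573 cells (Homo sapiens) for inhibition, read by sulforhodamine B assay, with a stated time of 48 h; a lower number here means a stronger inhibitor of growth, a higher number a weaker inhibitor of growth. Compound 1, `CC(=O)OC/C(=C\c1ccc(F)cc1)C(=O)c1ccccc1`, gives 4200 nM in this assay. Compound 2, `CC(=O)OC/C(=C\c1ccccc1F)C(=O)c1ccccc1`, differs from compound 1 by a single change, (2-fluorophenyl in place of 4-fluorophenyl on a double-bonded chain carbon bound to a double-bonded chain carbon), and in this assay compound 2 gives 6100 nM. The resulting step, a 1.5-fold higher number from compound 1 to compound 2 (0.16 log units; within the scatter), is small, so the two numbers cannot be told apart within the usual variation of the measurement.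

Compound 3, `C=C(C/C(=C\c1ccc(F)cc1)C(=O)c1ccccc1)C(=O)c1ccccc1`, is built on a different core; the difference between its core and that of compound 1 is not broken down here. In this assay compound 3 gives 3500 nM. Its number and those of compound 1 and compound 2 all lie within the scatter of one another, so no order can be read among the three.

Compound 4, `C=C(C/C(=C\c1ccccc1F)C(=O)c1ccccc1)C(=O)c1ccccc1`, has not yet been measured. It relates to compound 3 by the same change that turns compound 1 into compound 2, namely (2-fluorophenyl in place of 4-fluorophenyl on a double-bonded chain carbon bound to a double-bonded chain carbon). A step of similar size is expected for compound 3, namely a 1.4-fold higher number from compound 3 to compound 4 (0.15 log units; within the scatter), because on compound 1 that change gave a 1.5-fold higher number from compound 1 to compound 2 (0.16 log units; within the scatter), with the caveat that a single pair is a thin basis. Compound 4 is accordingly expected to give about 5000 nM in this assay, with a likely range from 3000 nM to 9000 nM.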

Compound 4, concentration for 50% growth inhibition: 3500 nM
The estimate for compound 4 lay 1.4-fold (0.15 log units) above the measured number; low and high end bracket the measured number.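

The change from 4-fluorophenyl to 2-fluorophenyl on the other core gives no change at the digits printed from compound 3 to compound 4 (within the scatter) in this assay. Set beside the same change on the core of compound 1, the new step does not differ from the earlier one: the same change on two cores in this assay, a 1.5-fold higher number (0.16 log units; within the scatter) from compound 1 to compound 2 and no change at the digits printed (within the scatter) from compound 3 to compound 4, 1.5-fold (0.16 log units) apart, within the scatter of two such steps. In these two pairs, then, the change carries from one core to the other without any gap that stands out from the scatter, but neither step lies beyond the scatter itself, so the data do not show that the change affects growth inhibition on either core, nor that the two cores would respond alike to a change large enough to be read.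

The compounds shown leave open what a group other than fluorine on the aromatic ring, such as a chlorine atom, a methoxy group, an amine or a carboxylic acid, would do at this place, and whether such a group would give a step beyond the scatter on both cores. Within the data shown here, they also leave open whether the agreement seen here would hold on any core beyond these two, since only two pairs are available and both were read in a single assay.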